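The source may report more compounds than this note shows. Statements on the series, on what has been measured and on what is new or still open speak of the compounds shown alone.

The measured compounds:
compound 1 `Clc1ccc(Nc2nc3c(N4CCCC4)ncnc3s2)cc1` gives 4260 nM
compound 2 `Fc1cccc(F)c1Nc1nc2c(Cl)ncnc2s1` gives 17200 nM
compound 3 `Clc1ncnc2sc(Nc3ccccc3)nc12` gives 3670 nM

All three numbers come from an assay on CHO cells for displacement of a labelled ligand from adenosine receptor A3 (Homo sapiens), read by scintillation counting, with a stated time of 3 h; on this read-out lower numbers stand for stronger inhibition and higher numbers for weaker inhibition. Compound 1 gives 4260 nM and stands second highest of the three. Compound 3, with 3670 nM, lies within the usual scatter of compound 1, so no order between those two can be claimed. Compound 2, at 17200 nM, lies beyond the scatter above compound 1 and is the weaker of that pair.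

Compound 4 `CN(C)c1ncnc2sc(Nc3ccc(Cl)cc3)nc12` has not yet been measured. It differs from compound 1 in one place: dimethylamino in place of pyrrolidin-1-yl on an aromatic carbon. The rest of the structure stays as it is. Going by the values given here, no pair of measured compounds shows a change of this kind, so there is no measured step to lean on. The group that enters has fewer heavy atoms than the one that leaves, with the same count of hydrogen-bond donors and acceptors; a step within the scatter is expected, or at most a small shift toward a higher number. The step from a 1.3-fold higher number from compound 1 to compound 4 (0.11 log units; within the scatter) is expected to be small. Compound 4 is therefore estimated at 5500 nM, with a range from 1800 nM to 17000 nM.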

Compound 4, inhibition constant: > 10000 nM
Compound 4 gave a limit, no number (the forecaster's own chance of this, stated with the estimate: 15%); middle value at least 1.8-fold (0.25 log units) from the limit.
By their numbers in this assay, from the lowest: compounds 3 and 1 (each within the scatter of the next); then compound 2.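

Going by these compounds alone, compound 1 and compound 4 differ only in the group on this aromatic carbon, and this is the first measured step at that position: an at least 2.3-fold higher number from compound 1 to compound 4 (0.37 log units; beyond the scatter). It shows that replacing pyrrolidin-1-yl, with its ring, by the smaller, open dimethylamino does not leave the result unchanged, even though the two groups have the same count of hydrogen-bond donors and acceptors. In this assay compound 4 gives > 10000 nM, which is a limit of the assay and not a number, so the step has a known lower end but no known full size: the limit of > 10000 nM in this assay, at which 1 of the 4 values shown sits.

The compounds shown leave open whether the difference follows the ring itself, its size or simply the number of heavy atoms, and a piperidin-1-yl or morpholin-4-yl group on this carbon would help to separate these readings. From the compounds shown here alone, it also remains open how a plain amine or a longer chain such as diethylamino would read here, and whether the same exchange would give a similar step with a different group on the aniline ring.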